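From 4-aminophenyl to 2-methylphenyl on the shared core

The source may report more compounds than this note shows. Statements on the series, on what has been measured and on what is new or still open speak of the compounds shown alone.

For the measured compounds named here, in a functional assay on MCF7 cells (Homo sapiens) for cytotoxicity, read by MTT assay, with a stated time of 96 h (on this read-out lower numbers stand for stronger inhibition and higher numbers for weaker inhibition), compound 1 `COc1cc(C(=O)c2cn(-c3ccccc3)cc2-c2ccc(N)cc2)cc(OC)c1OC` gives 9 nM and holds the lowest of the three numbers so far. Compound 2 `COc1cc(C(=O)c2cn(-c3ccccc3Cl)cc2-c2ccccc2)cc(OC)c1OC` gives 1800 nM and compound 3 `COc1cccc(-n2cc(C(=O)c3cc(OC)c(OC)c(OC)c3)c(-c3ccccc3)c2)c1` gives 500 nM and neither of them carries the 4-aminophenyl group. Compound 4 `COc1cc(C(=O)c2cn(-c3ccccc3)cc2-c2ccccc2C)cc(OC)c1OC` has not been measured yet. It has 2-methylphenyl in place of 4-aminophenyl on an aromatic carbon and so also lacks that group.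

Going by the values given here, the only measured step is a 3.6-fold lower number from compound 2 to compound 3 (0.56 log units; beyond the scatter) and it lies on the aromatic nitrogen, so it does not test this carbon directly. It does show that a change at that other place was modest. The larger gap separates compound 1 from the two compounds without 4-aminophenyl, with compound 3 at 500 nM as the closest of them. The step expected is therefore a large one, a 33-fold higher number from compound 1 to compound 4 (1.52 log units; beyond the scatter) in this assay towards weaker inhibition. Compound 4 is estimated at 300 nM with a range of 60 nM to 1500 nM expected for it.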

Compound 4, half-maximal inhibitory concentration: 190 nM
The estimate for compound 4 lay 1.6-fold (0.20 log units) above the measured number; measured number inside the range.
By their numbers in this assay, from the lowest: compound 1; then compound 4; then compound 3; then compound 2.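

For the compounds shown here, this is the first direct test of the aromatic carbon on the shared core: with 2-methylphenyl in place of 4-aminophenyl, this assay shows a 21-fold higher number from compound 1 to compound 4 (1.32 log units; beyond the scatter). The two groups match in size, with 7 heavy atoms each and one six-membered aromatic ring, yet the group that leaves has 1 hydrogen-bond donor and 1 hydrogen-bond acceptor, and the group that enters has neither, so a swap of equal size is enough to produce a large step. Nothing available explains why the number rises.

Still open is how much of the step belongs to losing the amine and how much to gaining the methyl: the compounds shown carry neither 2-aminophenyl nor 4-methylphenyl on this carbon. They also leave open whether another group in the place of the amine, such as a hydroxyl, would give a number close to that of compound 1.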